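This account rests on a few compounds, and the source may have more. Where it says the series, first, only, none or still open, it means among the compounds named here.

Of the compounds shown here, three built on one shared core have been tested in a functional assay on PC-3 cells (Homo sapiens) for cytotoxicity, read by XTT assay, with a stated time of 72 h; a higher number here means a weaker inhibitor, a lower number a stronger inhibitor. Compound 1, `COc1ccc(OC)c(-c2cc(-c3ccc(C(=O)N4CCCC4)s3)on2)c1`, carries a pyrrolidin-1-yl group on its carbonyl carbon. In this assay compound 1 gives > 30000 nM, which is a limit of the assay and not a number. Compound 2, `CCN(CC)C(=O)c1ccc(-c2cc(-c3cc(OC)ccc3OC)no2)s1`, differs from it only by a diethylamino group at that carbonyl carbon. In this assay compound 2 gives > 30000 nM, again only a limit. The step that the two limits leave unreadable from compound 1 to compound 2 therefore cannot be given a size. Compound 3, `O=C1C=CC(=O)C(c2cc(-c3ccc(C(=O)N4CCCC4)s3)on2)=C1`, changes the core elsewhere. In this assay compound 3 gives < 30000 nM, which is also only a limit. Compound 2 thus stands at the limit of > 30000 nM in this assay, at which 2 of the 3 values shown sit, together with compound 1, while compound 3 alone sits at the limit of < 30000 nM in this assay, at which 1 of the 3 values shown sits.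

Compound 4, `COc1ccc(OC)c(-c2cc(-c3ccc(C(=O)NCC4CC4)s3)on2)c1`, is not yet measured; it changes compound 2 by (cyclopropylmethyl)amino in place of diethylamino on a carbonyl carbon. Going by the values given here, the only measured step at the same carbonyl carbon is the one from compound 1 to compound 2, and it shows no readable size. Two different amine groups there, in compounds 1 and 2, both leave the value at a limit. The expected step that the limit leaves unreadable from compound 2 to compound 4 is therefore none beyond the scatter, most likely with the result again reported only as a limit. Compound 4 is estimated at 40000 nM, within 12000 nM to 130000 nM.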

Compound 4, half-maximal inhibitory concentration: > 30000 nM
Compound 4: a limit, no number (the forecaster's own chance of this, stated with the estimate: 75%); the middle value is on the limit's open side.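

In this assay compound 4 gives > 30000 nM, which is a limit of the assay and not a number, so the steps from compound 1 and from compound 2 to compound 4 cannot be read: the limit of > 30000 nM in this assay, at which 3 of the 4 values shown sit. The compounds shown leave open whether any amine group on this carbonyl carbon gives a measurable value.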